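The source may report more compounds than this note shows. Statements on the series, on what has been measured and on what is new or still open speak of the compounds shown alone.

Compound 1 `COc1ccc(Oc2ccc3c(NCCCNCc4cc(F)ccc4OC)ccnc3c2)cc1` gives 7000 nM in an ADME assay on HepG2 cells (Homo sapiens) for cytotoxicity, read by luminescence, CellTiter-Glo and ATP content, with a stated time of 72 h; on this read-out higher numbers stand for an effect only at larger amounts of compound and lower numbers for an effect already at smaller amounts; compound 2 `COc1ccc(Oc2ccc3c(NCCCNCc4cccc(OC)c4O)ccnc3c2)cc1` gives 5500 nM; compound 3 `COc1cccc(CNCCCNc2ccnc3cc(-c4cc(C(F)(F)F)cc(C(F)(F)F)c4)ccc23)c1O` gives 940 nM.

Compounds 1 and 2 share one core and differ only in the group on the chain: 5-fluoro-2-methoxyphenyl in place of 2-hydroxy-3-methoxyphenyl on a saturated chain carbon bound to an amine nitrogen. The step of a 1.3-fold higher number from compound 2 to compound 1 (0.10 log units; within the scatter) was small. Compound 3 carries a different core; how its core differs from that of compound 2 is not broken down here, yet compound 3 gives the lowest number of the three in this assay, a gap beyond the scatter to both compound 1 and compound 2.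

Compound 4 `COc1ccc(F)cc1CNCCCNc1ccnc2cc(-c3cc(C(F)(F)F)cc(C(F)(F)F)c3)ccc12` is not yet measured. It arises from compound 3 by the same change, (5-fluoro-2-methoxyphenyl in place of 2-hydroxy-3-methoxyphenyl on a saturated chain carbon bound to an amine nitrogen), at the same place. Since that change gave a 1.3-fold higher number from compound 2 to compound 1 (0.10 log units; within the scatter), a step of about a 1.3-fold higher number from compound 3 to compound 4 (0.11 log units; within the scatter) is expected from compound 3 to compound 4 in this assay. Compound 4 is therefore estimated at 1200 nM, with a likely range from 500 nM to 3000 nM.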

Compound 4, half-maximal effective concentration: 870 nM
For compound 4 the middle estimate is 1.4-fold (0.14 log units) above the measured one, within the range that was stated.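

In this assay, 5-fluoro-2-methoxyphenyl in place of 2-hydroxy-3-methoxyphenyl gave a 1.1-fold lower number from compound 3 to compound 4 (0.03 log units; within the scatter). Set beside the earlier step, the change reads the same on both cores: the same change on two cores in this assay, a 1.3-fold higher number (0.10 log units; within the scatter) from compound 2 to compound 1 and a 1.1-fold lower number (0.03 log units; within the scatter) from compound 3 to compound 4, 1.4-fold (0.14 log units) apart, within the scatter of two such steps. This shows that on these two cores the change moved the number by no more than the scatter, but it does not show that the same would hold on any other core, nor does it separate the two groups from each other.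

The change alters several parts of the ring at once, so the compounds shown leave open what a phenyl ring carrying only the fluorine or only the hydroxy group would give. As far as these compounds go, a longer chain on the amine nitrogen also remains open.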